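This account rests on a few compounds, and the source may have more. Where it says the series, first, only, none or still open, it means among the compounds named here.

Working notes on the series. The shared core of compound 1 `O=C(COc1cccc2ccccc12)N/N=C/c1ccc(Cl)cc1` carries an aryl group on a carbon with a double bond to nitrogen. In an ADME assay on HEL cells (Homo sapiens) for cytotoxicity (a higher number here means that more compound is tolerated, a lower number that less compound is tolerated), compound 1 gives 100 ug/mL. Compound 2 `O=C(COc1cccc2ccccc12)N/N=C/c1cccc(O)c1` in this assay gives 100 ug/mL, and the step of no change at the digits printed from compound 1 to compound 2 (within the scatter) shows that exchanging the aryl group at this position left the read-out unchanged within the scatter. Compound 3 `O=C(COc1cccc2ccccc12)N/N=C/c1ccccc1Br` stands only at a limit of this assay, where compound 3 gives >= 20 ug/mL. The steps a step that the limit leaves unreadable from compound 1 to compound 3 and a step that the limit leaves unreadable from compound 2 to compound 3 are therefore of unknown size, a consequence of the limit of >= 20 ug/mL in this assay, at which 1 of the 3 values shown sits.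

Compound 4 `O=C(COc1cccc2ccccc12)N/N=C/C=C/c1ccccc1` differs from compound 3 by 2-phenylethenyl in place of 2-bromophenyl on a carbon with a double bond to nitrogen. Going by the values given here, the only readable precedent for a change at this position is no change at the digits printed from compound 1 to compound 2 (within the scatter), which lies within the scatter; the steps a step that the limit leaves unreadable from compound 1 to compound 3 and a step that the limit leaves unreadable from compound 2 to compound 3 give no size. With two of three measured compounds at the same number and none showing a readable step beyond the scatter, no step beyond the scatter is expected for the change to compound 4 in this assay. Compound 4 is estimated at 100 ug/mL, with a range from 20 ug/mL to 200 ug/mL. The step that the limit leaves unreadable from compound 3 to compound 4 is what is expected.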

Compound 4, minimum cytotoxic concentration: 100 ug/mL
The estimate for compound 4 equals the measured number at the digits printed; the range from low to high includes it.
By their numbers in this assay, from the lowest: compounds 1, 2 and 4 (each within the scatter of the next).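

In this assay, putting 2-phenylethenyl in place of 3-hydroxyphenyl gives the step of no change at the digits printed from compound 2 to compound 4 (within the scatter), and putting it in place of 4-chlorophenyl gives the step of no change at the digits printed from compound 1 to compound 4 (within the scatter). The absence of a readable step at this position therefore now extends beyond the two substituted phenyl groups to a group with 1 double bond outside aromatic rings, although this remains a statement about compounds 1, 2 and 4 only. Compound 3 neither supports nor goes against it, and the steps to and from compound 3 cannot be read because its value is a limit: the limit of >= 20 ug/mL in this assay, at which 1 of the 4 values shown sits.

The compounds shown leave open whether any group on the carbon with a double bond to nitrogen produces a readable step beyond the scatter, for example a group carrying an amine or a carboxylic acid, or a saturated alkyl chain with no aromatic ring. They also leave open whether the same lack of change would hold if the rest of the shared core were altered.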